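The source may report more compounds than this note shows. Statements on the series, on what has been measured and on what is new or still open speak of the compounds shown alone.

Measured compounds in a functional assay on CRL2813 cells (Homo sapiens) for cytotoxicity, read by sulforhodamine B assay, with a stated time of 5 days; on this read-out lower numbers stand for stronger inhibition and higher numbers for weaker inhibition:

- compound 1, `CSc1ccccc1NC(=O)N[C@H]1CC[C@H](Oc2ccc(F)cc2)CC1` — compound 1 gives > 20000 nM, which is a limit of this assay and not a number
- compound 2, `Cc1cccc(NC(=O)N[C@H]2CC[C@H](Oc3ccc(F)cc3)CC2)c1` — compound 2 gives 14400 nM
- compound 3, `O=C(Nc1ccccc1OC(F)(F)F)N[C@H]1CC[C@H](Oc2ccc(F)cc2)CC1` — compound 3 gives > 20000 nM, again a limit and not a number

Compound 3 therefore stands at the edge of what this assay can report; it is one of the two compounds sitting at the limit of > 20000 nM in this assay, at which 2 of the 3 values shown sit. The step that the two limits leave unreadable from compound 1 to compound 3 cannot be read for that reason. For the measured compounds named here, the only readable step among the three, an at least 1.3-fold lower number from compound 1 to compound 2 (0.14 log units; that floor lies within the scatter), is small enough to lie within the scatter of repeated measurements.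

Compound 4, `O=C(Nc1ccccc1I)N[C@H]1CC[C@H](Oc2ccc(F)cc2)CC1`, is the next compound. It differs from compound 3 by iodo in place of trifluoromethoxy on an aromatic carbon. Both measured steps change the group at the same kind of position on the shared core, and neither of them produced a movement that stands clearly outside the scatter. Going by the values given here, no step in this set shows a change at that position pulling a compound away from the limit. The expected step that the limit leaves unreadable from compound 3 to compound 4 is thus no more than the scatter allows, with the number staying near the limit. Compound 4 is expected to give about 25000 nM in this assay, within a range from 8000 nM to 80000 nM.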

Compound 4, half-maximal inhibitory concentration: > 20000 nM
Compound 4 was reported as a limit (the forecaster's own chance of this, stated with the estimate: 65%); the middle value is on the limit's open side.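

In this assay compound 4 gives > 20000 nM, which is a limit and not a number. Iodo is a single heavy atom and trifluoromethoxy has five, yet putting one in place of the other on this aromatic carbon, ortho to a large group, leaves the result at the edge of what the test can report, and methylsulfanyl, trifluoromethoxy and iodo now all end there, so the steps among those three compounds cannot be read: the limit of > 20000 nM in this assay, at which 3 of the 4 values shown sit. For the compounds shown here, the one step that can be read, an at least 1.3-fold higher number from compound 2 to compound 4 (0.14 log units; that floor lies within the scatter), comes with 2-iodophenyl in place of 3-methylphenyl on the amide-type nitrogen and does not separate the two compounds.

On these data alone, how far the true values of the three limit compounds lie beyond what the test reports stays unknown, so methylsulfanyl, trifluoromethoxy and iodo cannot be ranked against one another. As far as these compounds go, whether an amine or a carboxylic acid on this aromatic carbon would bring the number into the readable range, clearly away from the limit, also remains open.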